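The compounds below may be only part of what the source reports. "The series", "measured", "known", "first", "only" and "open" are said of these compounds alone.

Of the compounds shown here, two have so far been measured in a functional assay on A-431 cells (Homo sapiens) for antiproliferative activity, read by MTT assay, with a stated time of 72 h; on this read-out lower numbers stand for stronger inhibition and higher numbers for weaker inhibition. Compound 1 `CN1CCN(Cc2ccc(NC(=O)Nc3ccc4ncnc(Nc5ccc(F)c(Cl)c5)c4c3)cc2)CC1` gives 4000 nM in this assay. Compound 2 `COC(=O)c1cccc(Nc2ncnc3ccc(NC(=O)Nc4ccc(CN5CCN(C)CC5)cc4)cc23)c1` gives 5630 nM in this assay. The two structures differ in one place only, and the step between them is a 1.4-fold higher number from compound 1 to compound 2 (0.15 log units; within the scatter). Going by the values given here, compound 2 therefore carries the higher of the two numbers, but its only neighbour, compound 1, sits at a distance the scatter covers, so the two cannot be ranked against each other.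

Compound 3 `C[C@@H](Nc1ncnc2ccc(NC(=O)Nc3ccc(CN4CCN(C)CC4)cc3)cc12)c1ccccc1` has not yet been measured. It differs from compound 2 in one place: 1-phenylethyl in place of 3-(methoxycarbonyl)phenyl on a nitrogen on an aromatic ring. Among the compounds with values here, the one measured step exchanged one aromatic group for another on that same nitrogen and stayed within the scatter; no measured pair exchanges an aromatic group for a 1-phenylethyl group, so the new change has no direct precedent in these data. With nothing pointing either way, the step from compound 2 to compound 3 is expected to be a 1.1-fold lower number from compound 2 to compound 3 (0.05 log units; within the scatter), none beyond the scatter, with a wide allowance for the missing guidance. Compound 3 is accordingly estimated at 5000 nM in this assay, within a range of 1500 nM to 17000 nM.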

Compound 3, half-maximal inhibitory concentration: > 10000 nM
Compound 3 gave a limit, no number (the forecaster's own chance of this, stated with the estimate: 5%); middle value at least 2.0-fold (0.30 log units) away from the limit.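

In this assay, going by these compounds alone, the change from 3-chloro-4-fluorophenyl to 1-phenylethyl on this nitrogen gives an at least 2.5-fold higher number from compound 1 to compound 3 (0.39 log units; beyond the scatter), so this position does respond to what it carries, although the one earlier exchange, between two aromatic groups, stayed within the scatter. The change from 3-(methoxycarbonyl)phenyl to 1-phenylethyl gives an at least 1.7-fold higher number from compound 2 to compound 3 (0.24 log units; that floor lies within the scatter), which on its own does not separate those two compounds, so the evidence for weaker activity with 1-phenylethyl rests on the comparison with compound 1. For compound 3 the result is a limit of the assay and not a number, so the true size of both steps stays unknown: the limit of > 10000 nM in this assay, at which 1 of the 3 values shown sits.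

The compounds shown leave open how much of this loss belongs to the 1-phenylethyl group as a whole and how much to its defined stereocentre, since the mirror-image form of that group does not appear among them. They also leave open whether a plain benzyl group on this nitrogen would read like compound 3 or like compound 1.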